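The source may report more compounds than this note shows. Statements on the series, on what has been measured and on what is new or still open speak of the compounds shown alone.

Measured in an assay on brain for displacement of a labelled ligand from D(3) dopamine receptor (Rattus norvegicus); a higher number here means a weaker inhibitor, a lower number a stronger inhibitor:
compound 1 `CCCN(CC[C@H]1CC[C@H](NC(=O)/C=C/c2ccc(OC)cc2)CC1)[C@H]1CCc2nc(N)sc2C1`, 6.7 nM
compound 2 `CCCN(CC[C@H]1CC[C@H](NC(=O)/C=C/c2cccc(OC)c2)CC1)[C@H]1CCc2nc(N)sc2C1`, 9.3 nM

Among the measured compounds shown here, compound 2 carries the higher of the two numbers in this assay, but the single measured step, a 1.4-fold higher number from compound 1 to compound 2 (0.14 log units; within the scatter), lies within the scatter, so compound 1 and compound 2 are not separable on these data. Compound 3 `CCCN(CC[C@H]1CC[C@H](NC(=O)c2ccc(-n3ccnc3)cc2)CC1)[C@H]1CCc2nc(N)sc2C1` differs from compound 2 by 4-(1H-imidazol-1-yl)phenyl in place of 2-(3-methoxyphenyl)ethenyl on a carbonyl carbon. For the measured compounds named here, no measured step bears on this change: the one step known concerns only the methoxy position and says nothing about exchanging the 2-(3-methoxyphenyl)ethenyl group for a 4-(1H-imidazol-1-yl)phenyl group. A modest weakening is expected, a 1.6-fold higher number from compound 2 to compound 3 (0.21 log units; within the scatter), with a wide margin. Compound 3 is estimated at 15 nM, ranging from 4 nM to 60 nM.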

Compound 3, inhibition constant: 1.9 nM
For compound 3 the middle estimate is 7.9-fold (0.90 log units) above the measured one, and the stated range ends above it.
By their numbers in this assay, from the lowest: compound 3; then compounds 1 and 2 (each within the scatter of the next).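

Exchanging 2-(3-methoxyphenyl)ethenyl for 4-(1H-imidazol-1-yl)phenyl on the carbonyl carbon gives a 4.9-fold lower number from compound 2 to compound 3 (0.69 log units; beyond the scatter) in this assay, and the same exchange from 2-(4-methoxyphenyl)ethenyl gives a 3.5-fold lower number from compound 1 to compound 3 (0.55 log units; beyond the scatter). Unlike the methoxy shift, the group change at this carbonyl carbon moves the number beyond the scatter, and a low number here does not need the double bond outside the rings. No available evidence bears on this result.

The exchange removes the double bond and adds the imidazole ring together, so their separate contributions stay unresolved. Going by these compounds, how a plain phenyl or a 4-aminophenyl on this carbonyl carbon would compare remains open.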